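Meta Chloro for Trifluoromethyl on a Carbamate Aryl Group

The source may report more compounds than this note shows. Statements on the series, on what has been measured and on what is new or still open speak of the compounds shown alone.

Compound 2 `CCCCOc1ccc(CNC(=O)Oc2cccc(C(F)(F)F)c2)cc1` shows the lowest of the two numbers measured in an assay on H4 cells for inhibition of Fatty-acid amide hydrolase 1 (Homo sapiens) (on this read-out higher numbers stand for weaker inhibition and lower numbers for stronger inhibition), where compound 2 gives 40 nM; its nearest neighbour is compound 1 `CCCCOc1ccc(C(CC)NC(=O)Oc2cccc(C(F)(F)F)c2)cc1`, which in this assay gives 51 nM, a gap within the scatter, as a 1.3-fold lower number from compound 1 to compound 2 (0.11 log units; within the scatter) records. Compound 3 `CCCCOc1ccc(CNC(=O)Oc2cccc(Cl)c2)cc1` differs from compound 2 by chloro in place of trifluoromethyl on an aromatic carbon. Going by the values given here, no measured step touches this exchange, since the only step known concerns the chain carbon bound to the amide-type nitrogen. Compound 3 is therefore expected to show no step beyond the scatter, namely a 1.5-fold higher number from compound 2 to compound 3 (0.18 log units; within the scatter), with an estimate of 60 nM in this assay, ranging from 20 nM to 200 nM.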

Compound 3, half-maximal inhibitory concentration: 12 nM
Compound 3: the middle estimate sits 5.0-fold (0.70 log units) above what was measured, and the stated range ends above it.
By their numbers in this assay, from the lowest: compound 3; then compounds 2 and 1 (each within the scatter of the next).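

Exchanging trifluoromethyl for chloro on this aromatic carbon gives, in this assay, the first step beyond the scatter among these compounds: a 3.3-fold lower number from compound 2 to compound 3 (0.52 log units; beyond the scatter). This position therefore responds to the group it carries, whereas the change at the chain carbon between compound 1 and compound 2 stayed within the scatter. Nothing at hand bears on the cause of this step. As far as these compounds go, whether bromo, methyl or methoxy at this place would match chloro remains open. So does whether ethyl on the chain carbon would still leave the number within the scatter with chloro in place.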